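Monoester analogues of a diester nucleoside in a leukaemia cell assay

The compounds below may be only part of what the source reports. "The series", "measured", "known", "first", "only" and "open" are said of these compounds alone.

Measured so far:
compound 1 `CCCC(CCC)C(=O)OC[C@H]1O[C@@H](n2cnc3c(N)ncnc32)[C@H](OC(=O)C(CCC)CCC)[C@]1(C)O` — 51900 nM
compound 2 `CCCC(CCC)C(=O)O[C@H]1[C@H](n2cnc3c(N)ncnc32)O[C@H](CO)[C@@]1(C)O` — 500000 nM
compound 3 `CCCC(CCC)C(=O)Nc1ncnc2c1ncn2[C@@H]1O[C@H](COC(=O)C(CCC)CCC)[C@@](C)(O)[C@H]1OC(=O)C(CCC)CCC` — "nd(insoluble)" (no result reported)

In a functional assay on K562 cells (Homo sapiens) for inhibition, read by MTT assay, with a stated time of 48 h (on this read-out lower numbers stand for stronger inhibition and higher numbers for weaker inhibition), compound 1 gives 51900 nM, the lowest of the two numbers in hand. Compound 2 gives 500000 nM; the step of a 9.6-fold higher number from compound 1 to compound 2 (0.98 log units; beyond the scatter) is a modest one, beyond the scatter. Compound 3, the triester with an amide on the base, was insoluble and gave "nd(insoluble)" (no result reported), so no number stands for it.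

The unmeasured compound 4 `CCCC(CCC)C(=O)OC[C@H]1O[C@@H](n2cnc3c(N)ncnc32)[C@H](O)[C@]1(C)O` is related to compound 1 by hydrogen in place of (1-propylbutyl)carbonyl on an oxygen on a saturated carbon. Going by the values given here, this is the same kind of change as the one from compound 1 to compound 2, but at the other ester: compound 2 kept the ester on the ring oxygen and lost the one on the chain, whereas compound 4 keeps the chain ester and loses the ring one. Among the compounds with values here, the only step that bears on it is a 9.6-fold higher number from compound 1 to compound 2 (0.98 log units; beyond the scatter), which moved the number up. Loss of one acyl group is therefore expected to raise the number again, though the size at this second site is not settled by one step at the other, so the expected step of a 3.9-fold higher number from compound 1 to compound 4 (0.59 log units; beyond the scatter) is set a little smaller than the one seen. Compound 4 is thus estimated at 200000 nM, with a plausible range from 60000 nM to 500000 nM.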

Compound 4, half-maximal inhibitory concentration: 200000 nM
Compound 4: the middle estimate sits on the measured number at the digits printed, and the stated range covers the measured number.
By their numbers in this assay, from the lowest: compound 1; then compound 4; then compound 2.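

Removing the (1-propylbutyl)carbonyl group from the oxygen on a saturated carbon whose other neighbour is a saturated ring carbon gives a 3.9-fold higher number from compound 1 to compound 4 (0.59 log units; beyond the scatter) in this assay and lies beyond the scatter. Read with a 9.6-fold higher number from compound 1 to compound 2 (0.98 log units; beyond the scatter) for the other ester of compound 1, this shows that the loss of either acyl group, taken alone, moves the number the same way; among compounds 1, 2 and 4, none goes against this, and compound 1, which carries both esters, has the lowest number. No measurement in hand accounts for either step, and none shows what the ester contributes inside the cells.

Still open, from the compounds shown here alone, is whether an acetyl group or a longer unbranched acyl chain on these oxygens would hold, lower or raise the number of compound 1, and whether an amide link in place of the ester would read the same way. Compound 3 gives no number, so the effect of a (1-propylbutyl)carbonyl group on the amine of the base remains unread, and a smaller acyl group on that amine would be needed to address it.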